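The source may hold more compounds than are shown below. What is called first, only, known or untested is meant among the compounds shown, and "the series" means these compounds.

Measured so far in a functional assay on Raji cells (Homo sapiens) for inhibition, read by MTT assay, with a stated time of 96 h; on this read-out lower numbers stand for an effect already at smaller amounts and higher numbers for an effect only at larger amounts of compound:
compound 1, `CC(C)Cn1c(=O)n(C)c(=O)c2c1nc(Cc1cccc3ccccc13)c(=O)n2CCCCO`: 150 nM
compound 2, `CC(C)Cn1c(=O)n(C)c(=O)c2c1nc(Cc1cccc3ccccc13)c(=O)n2CCCCCO`: 1420 nM
compound 3, `CC(C)Cn1c(=O)n(C)c(=O)c2nc(CCCCCO)c(Cc3cccc4ccccc34)nc21`: 58 nM

In this assay compound 3 gives the lowest of the three numbers, with compound 1 nearest and compound 2 furthest away. Compound 1 and compound 2 differ by one change, (hydroxymethyl in place of hydroxy on a saturated chain carbon, four bonds along the chain from an aromatic nitrogen), and that change made a step of a 9.5-fold higher number from compound 1 to compound 2 (0.98 log units; beyond the scatter).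

Compound 4, `CC(C)Cn1c(=O)n(C)c(=O)c2nc(CCCCCCO)c(Cc3cccc4ccccc34)nc21`, is not yet measured. It differs from compound 3 by hydroxymethyl in place of hydroxy on a saturated chain carbon, five bonds along the chain from an aromatic carbon. This is the same kind of change as that from compound 1 to compound 2, but not the same: there the group sits on a saturated chain carbon four bonds along the chain from an aromatic nitrogen, here on a saturated chain carbon five bonds along the chain from an aromatic carbon. How the core of compound 1 and the core of compound 3 differ is not broken down here.

Going by the values given here, the expectation for compound 4 rests on the one measured instance, a 9.5-fold higher number from compound 1 to compound 2 (0.98 log units; beyond the scatter), made on a different core and chain. The step from compound 3 to compound 4 is estimated at a 6.0-fold higher number from compound 3 to compound 4 (0.78 log units; beyond the scatter), taken somewhat smaller than the measured one since the surroundings differ. Compound 4 is thus expected to give about 350 nM, with an estimated range from 120 nM to 1100 nM.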

Compound 4, half-maximal effective concentration: 1690 nM
Compound 4: the middle estimate sits 4.8-fold (0.68 log units) below what was measured; the measured number lies above the stated range.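

In this assay the change from hydroxy to hydroxymethyl on the chain gives a 29-fold higher number from compound 3 to compound 4 (1.46 log units; beyond the scatter) on the core of compound 3, a higher number in the same direction as on the core of compound 1. Going by these compounds alone, in these two pairs the direction of the step carried over from one core to the other, but this is only two pairs and does not show why the sizes part, since core, chain length and place of the chain all differ together between them. The size did not carry over, so a step read on one core gives its direction here but not a dependable size on the other: the same change on two cores in this assay, a 9.5-fold higher number (0.98 log units; beyond the scatter) from compound 1 to compound 2 and a 29-fold higher number (1.46 log units; beyond the scatter) from compound 3 to compound 4, 3.1-fold (0.49 log units) apart, beyond the scatter of two such steps.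

Still open, from the compounds shown here alone, is how the number moves with a shorter chain on each core, and whether the trend holds for a longer chain. Also open, going by these compounds, is whether the chain end needs to be a hydroxy group at all, or whether an amine or a carboxylic acid there would fit the same pattern.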